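The compounds below may be only part of what the source reports. "The series", "measured", "known", "first", "only" and "open" are said of these compounds alone.

Compound 1 `COC(=O)c1cc(OCC(=O)[C@H](CC(=O)O)NC(=O)[C@@H](NC(=O)COc2cccc3ccccc23)C(C)C)no1` gives 71000 nM in a functional assay on Jurkat cells (Homo sapiens) for inhibition; a lower number here means a stronger inhibitor, a higher number a weaker inhibitor. Compound 2 `CC(C)[C@H](NC(=O)COc1cccc2ccccc12)C(=O)N[C@@H](CC(=O)O)C(=O)CSc1nc(-c2ccccc2)cs1` gives > 200000 nM, which is a limit of the assay. Compound 3 `Cc1cc(C)nc(SCC(=O)[C@H](CC(=O)O)NC(=O)[C@@H](NC(=O)COc2cccc3ccccc23)C(C)C)n1` gives > 200000 nM, also a limit of the assay.

Among the compounds with values here, compound 1 thus stands as the only compound with a number in this assay, the other two sitting at the limit of > 200000 nM in this assay, at which 2 of the 3 values shown sit. Compound 4 `CC(C)[C@H](NC(=O)COc1cccc2ccccc12)C(=O)N[C@@H](CC(=O)O)C(=O)COc1nccc(C(F)(F)F)n1` differs from compound 1 as follows: 4-(trifluoromethyl)pyrimidin-2-yl in place of 5-(methoxycarbonyl)-1,2-oxazol-3-yl on an oxygen on a saturated carbon. Within the data shown here, the steps that bear on this are an at least 2.8-fold higher number from compound 1 to compound 2 (0.44 log units; beyond the scatter) and an at least 2.8-fold higher number from compound 1 to compound 3 (0.44 log units; beyond the scatter); each replaced the (5-(methoxycarbonyl)-1,2-oxazol-3-yl)oxy group and each weakened inhibition. The step that the two limits leave unreadable from compound 2 to compound 3 adds nothing readable. Compound 4 keeps the oxygen link but swaps the ring, so a weakening of similar size is expected, estimated as a 2.3-fold higher number from compound 1 to compound 4 (0.35 log units; beyond the scatter). Compound 4 is therefore expected to give 160000 nM in this assay, estimated between 50000 nM and 450000 nM.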

Compound 4, half-maximal inhibitory concentration: > 200000 nM
Compound 4: only a limit was reported; the forecaster's own chance of this, stated with the estimate: 40%; middle value at least 1.2-fold (0.09 log units) away from the limit.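

In this assay, the step with the oxygen link kept and only the ring changed gives an at least 2.8-fold higher number from compound 1 to compound 4 (0.44 log units; beyond the scatter). The earlier steps shown here changed link and ring together, so sulfur in the link is not required for this loss. The steps from compound 2 and from compound 3 to compound 4 cannot be read, as each joins two limits: the limit of > 200000 nM in this assay, at which 3 of the 4 values shown sit.

Still open, going by these compounds, is whether the methoxycarbonyl itself or the 1,2-oxazole ring supports the measurable activity of compound 1. A carboxylic acid or a primary amide in place of the methoxycarbonyl would separate these.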